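Series notes: trifluoromethyl removal and antiproliferative inhibition

A few compounds are considered here, and "the series" means these few. Any claim that something is new, unique, unknown or untested is made for them only; others in the source may bear on it.

Measured compounds in a functional assay on BGC-823 cells (Homo sapiens) for antiproliferative activity, read by sulforhodamine B assay, tested at 100 ug/mL; a lower number here means less inhibition, a higher number more inhibition at the concentration tested (going by the name of the read-out):
compound 1 `O=C1CCCCC1S(=O)(=O)Nc1ccc(Cl)cc1C(F)(F)F`: 36.4%
compound 2 `O=C1CCCCC1S(=O)(=O)Nc1ccc(Cl)cc1`: 16%
compound 3 `O=C1CCCCC1S(=O)(=O)Nc1cc(C(F)(F)F)cc(C(F)(F)F)c1`: 70.8%

The step of a number 20.4 percentage points lower from compound 1 to compound 2 (beyond the scatter) goes with hydrogen in place of trifluoromethyl on an aromatic carbon. Compound 3 stands highest of the three, beyond the scatter from compound 1 and from compound 2 alike; how the core of compound 3 differs from the core of compound 1 is not broken down here.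

Compound 4 `O=C1CCCCC1S(=O)(=O)Nc1cccc(C(F)(F)F)c1` is not yet measured in this assay. It differs from compound 3 by hydrogen in place of trifluoromethyl on an aromatic carbon. Among the measured compounds shown here, this is the same kind of change as the one from compound 1 to compound 2, not the same: in compound 1 the leaving group sits ortho to a large group and meta to a chloro group, in compound 3 it sits meta to a large group and meta to a trifluoromethyl group.

Compound 4 is expected to drop by about a number 23.8 percentage points lower from compound 3 to compound 4 (beyond the scatter), resting on the earlier step of a number 20.4 percentage points lower from compound 1 to compound 2 (beyond the scatter). The expected value for compound 4 is 47%, likely between 27% and 65%.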

Compound 4, a percentage reported as inhibition, at one concentration (the size of the read-out at that concentration, not a potency): 21.7%
Compound 4: the middle estimate sits 25.3 percentage points above what was measured; the whole stated range lies above it.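

In this assay, hydrogen in place of trifluoromethyl on an aromatic carbon comes with a number 49.1 percentage points lower from compound 3 to compound 4 (beyond the scatter). The direction matches the earlier step, but its size does not carry over from one core to the other: the same change on two cores in this assay, a number 20.4 percentage points lower (beyond the scatter) from compound 1 to compound 2 and a number 49.1 percentage points lower (beyond the scatter) from compound 3 to compound 4, 28.7 percentage points apart, beyond the scatter of two such steps These two pairs show that a step read on one core cannot be applied unchanged to the other; they do not show which difference between the cores, the chloro group or the place of the trifluoromethyl that leaves, accounts for the gap.

Still open, on these data alone, is whether the direction holds on further cores. Also open, as far as these compounds go, is what a nitrile or a carboxylic acid would give in place of that trifluoromethyl.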